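Cytotoxicity limits for a set of quinazoline-type anilides

This account rests on a few compounds, and the source may have more. Where it says the series, first, only, none or still open, it means among the compounds named here.

Measured compounds and their values:
- Compound 1 `COc1cc2nc(Nc3ccc(C#N)cc3)nc(Nc3c(C)cc(/C=C/C#N)cc3F)c2cc1OC`, in an ADME assay on MT4 cells (Homo sapiens) for cytotoxicity, read by MTT assay, with a stated time of 5 days; a lower number here means that less compound is tolerated, a higher number that more compound is tolerated: > 52000 nM
- Compound 2 `COc1cc2nc(SCC(=O)Nc3ccc(C#N)cc3)nc(Nc3c(C)cc(/C=C/C#N)cc3C)c2cc1OC`, in this assay: > 227000 nM
- Compound 3 `COc1cc2nc([S+]([O-])CC(=O)Nc3cccc([N+](=O)[O-])c3)nc(Nc3c(Cl)cc(/C=C/C#N)cc3Cl)c2cc1OC`, in this assay: >= 83200 nM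

None of the three values above is a true number. The value for compound 1 is a limit of the assay (the limit of > 52000 nM in this assay, at which 1 of the 3 values shown sits). The value for compound 2 is likewise a limit (the limit of > 227000 nM in this assay, at which 1 of the 3 values shown sits). Compound 3 also gives only a limit (the limit of >= 83200 nM in this assay, at which 1 of the 3 values shown sits), so its place among the three cannot be ranked; all that can be said is that no toxic concentration was reached for any of them within the tested range.

Compound 4 `COc1cc2nc([S+]([O-])CC(=O)Nc3ccc(C#N)cc3)nc(Nc3c(Cl)cc(/C=C/C#N)cc3Cl)c2cc1OC` differs from compound 3 in one place: 4-cyanophenyl in place of 3-nitrophenyl on an amide-type nitrogen. The two structures are otherwise the same, including the shared core and the group on the other amine.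

With no measured step between any two of the compounds shown, and every value resting at a limit, there is no basis for expecting a change beyond the usual scatter in this assay. The expected step from compound 3 to compound 4 is therefore essentially flat, an at least 1.0-fold lower number from compound 3 to compound 4 (0.01 log units; that floor lies within the scatter). Compound 4 is accordingly estimated at 80000 nM, with a range from 30000 nM to 250000 nM, and most likely the assay will again report only a limit.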

Compound 4, half-maximal cytotoxic concentration: >= 188000 nM
Compound 4: a limit, no number; the forecaster's own chance of this, stated with the estimate: 85%; at least 2.3-fold (0.37 log units) between middle value and limit.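

In this assay compound 4 gives >= 188000 nM, which is a limit and not a number. For the compounds shown here, compound 3 also rests at a limit, and no step from compound 3 to compound 4 can be read. The compounds shown leave open at what concentration any of them becomes toxic to these cells, and whether 4-cyanophenyl in place of 3-nitrophenyl alters that concentration.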